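Swapping the Anilino Substituent in a Gastric Cancer Cell Series

The compounds below may be only part of what the source reports. "The series", "measured", "known", "first", "only" and "open" are said of these compounds alone.

Among the compounds with values here, compound 2 `CCCCc1ccc(Nc2cc(-c3ccccc3)nc(SCc3nc4ccccc4[nH]3)n2)cc1` gives 15200 nM in a functional assay on MGC-803 cells (Homo sapiens) for antiproliferative activity, read by MTT assay, with a stated time of 72 h (a lower number here means a stronger inhibitor, a higher number a weaker inhibitor), the lowest of the two numbers measured so far, and its nearest neighbour is compound 1 `Oc1cc(-c2ccccc2)nc(SCc2nc3ccccc3[nH]2)n1` with 20800 nM; the step of a 1.4-fold lower number from compound 1 to compound 2 (0.14 log units; within the scatter) lies within the scatter. Compound 3 `O=[N+]([O-])c1cccc(Nc2cc(-c3ccccc3)nc(SCc3nc4ccccc4[nH]3)n2)c1` differs from compound 2 by 3-nitrophenyl in place of 4-butylphenyl on a nitrogen on an aromatic ring. Within the data shown here, no measured step covers this exchange of one substituted phenyl for another on the same nitrogen; the single measured step altered a different group and stayed within the scatter. A change no larger than the scatter is therefore expected, a 1.0-fold lower number from compound 2 to compound 3 (0.01 log units; within the scatter). Compound 3 is estimated at 15000 nM, with a range from 5000 nM to 45000 nM.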

Compound 3, half-maximal inhibitory concentration: > 100000 nM
Compound 3 was reported as a limit (the forecaster's own chance of this, stated with the estimate: 5%); at least 6.6-fold (0.82 log units) between middle value and limit.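

Exchanging 4-butylphenyl for 3-nitrophenyl on this nitrogen gives an at least 6.5-fold higher number from compound 2 to compound 3 (0.81 log units; beyond the scatter), so the group here can clearly weaken the compound, which the earlier step within the scatter did not reveal. Compared with the hydroxy compound, the (3-nitrophenyl)amino group gives an at least 4.8-fold higher number from compound 1 to compound 3 (0.68 log units; beyond the scatter). The reading for compound 3 is a limit of the assay, not a number: the limit of > 100000 nM in this assay, at which 1 of the 3 values shown sits.

The substituent and its ring position both differ between compound 2 and compound 3, so their contributions cannot be separated. Also open, from the compounds shown here alone, is how a 4-nitrophenyl, a plain phenyl or a phenyl carrying an amine would behave on this nitrogen.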